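Methylamino Glycinamide on a Second Chromene Core

The source may report more compounds than this note shows. Statements on the series, on what has been measured and on what is new or still open speak of the compounds shown alone.

Measured compounds in a functional assay on HeLa cells (Homo sapiens) for antiproliferative activity, read by MTT assay, with a stated time of 48 h; a higher number here means a weaker inhibitor, a lower number a stronger inhibitor:
compound 1 `COc1ccc(C(=O)c2ccc(OC)c3c2C=CC(C)(C)O3)c(NC(=O)CN)c1` gives 100 nM
compound 2 `COc1ccc(C(=O)c2ccc3c(c2)C=CC(C)(C)O3)c(NC(=O)CN)c1` gives 580 nM
compound 3 `CNCC(=O)Nc1cc(OC)ccc1C(=O)c1ccc(OC)c2c1C=CC(C)(C)O2` gives 2170 nM

Compound 3 is made from compound 1 by methyl in place of hydrogen on an amine nitrogen, and this change gave a 22-fold higher number from compound 1 to compound 3 (1.34 log units; beyond the scatter). Compound 2 differs from compound 1 in its core, a difference that is not broken down here; in this assay compound 2 sits between the other two. Compound 4 `CNCC(=O)Nc1cc(OC)ccc1C(=O)c1ccc2c(c1)C=CC(C)(C)O2` is made from compound 2 by methyl in place of hydrogen on an amine nitrogen, the same change at the same place on the core of compound 2. For the measured compounds named here, since the only measured example of this change is the step from compound 1 to compound 3, compound 4 is expected to follow a step of a 14-fold higher number from compound 2 to compound 4 (1.14 log units; beyond the scatter), a little smaller because the core of compound 2 already gives 580 nM. Compound 4 is therefore estimated at 8000 nM, between 2500 nM and 30000 nM.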

Compound 4, half-maximal inhibitory concentration: 970 nM
Beside the measured number, compound 4's estimate is 8.2-fold (0.92 log units) above it; measured number below the stated range.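

In this assay, methyl in place of hydrogen on the amine nitrogen gave a 1.7-fold higher number from compound 2 to compound 4 (0.22 log units; within the scatter), so on the core of compound 2 this change cannot be told apart from the scatter. The size of the step does not carry over from one core to the other: the same change on two cores in this assay, a 22-fold higher number (1.34 log units; beyond the scatter) from compound 1 to compound 3 and a 1.7-fold higher number (0.22 log units; within the scatter) from compound 2 to compound 4, 13-fold (1.11 log units) apart, beyond the scatter of two such steps. For the compounds shown here, with only one pair on each core, this shows that the size of the step differs between these two cores, but it does not show which feature of the cores accounts for the difference or how the change would behave on a further core.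

The compounds shown leave open how either core would respond to an ethyl group or a second methyl on that nitrogen. They also leave open what a longer chain between the amide carbonyl and the amine would do.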